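Fluoro to Dimethylamino on a Shared Dienone Core

The source may report more compounds than this note shows. Statements on the series, on what has been measured and on what is new or still open speak of the compounds shown alone.

Of the compounds shown here, three have been measured in a physicochemical assay for lipophilicity; on this read-out lower numbers stand for lower lipophilicity and higher numbers for higher lipophilicity. Compound 2 `O=C1/C(=C/c2ccc(F)cc2)CCC/C1=C\c1ccc([N+](=O)[O-])cc1` gives 5.08, the top figure of the three, yet its gaps to the other two lie within the usual scatter, so nothing separates them. Compound 1 `Cc1ccc(/C=C2\CCC/C(=C\c3cccc([N+](=O)[O-])c3)C2=O)cc1` gives 5.06, and compound 3 `Cc1ccc(/C=C2\CCC/C(=C\c3ccccc3[N+](=O)[O-])C2=O)cc1` gives 4.86 in this assay.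

Compound 4 `CN(C)c1ccc(/C=C2\CCC/C(=C\c3ccc([N+](=O)[O-])cc3)C2=O)cc1` has not yet been measured. It differs from compound 2 in one place: dimethylamino in place of fluoro on an aromatic carbon. Among the compounds with values here, no pair of measured compounds shows this swap, so nothing here points to a direction. The step expected a number 0.08 log units lower from compound 2 to compound 4 (within the scatter) is small, likely no larger than the scatter. Compound 4 is therefore expected near 5, with a range from 4.5 to 5.5.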

Compound 4, partition coefficient: 5.08
Compound 4: the middle estimate sits 0.08 log units below what was measured; the measured number falls inside the stated range.
By their numbers in this assay, from the lowest: compounds 3, 1, 2 and 4 (each within the scatter of the next).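

In this assay the swap of fluoro for dimethylamino on this aromatic carbon, para to a large group, gives no change at the digits printed from compound 2 to compound 4 (within the scatter) and is the first reading of a change in one place among these compounds. At this position, then, the larger dimethylamino group and the single fluorine cannot be told apart on this read-out. Nothing shown here accounts for that result.

Other groups at this position, such as a carboxylic acid or a longer alkyl chain, remain open. So does whether this same swap would read alike on the core of compound 1 or compound 3.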